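From pyrrolidin-1-yl compound 3 to compound 4

The source may hold more compounds than are shown below. What is called first, only, known or untested is meant among the compounds shown, and "the series" means these compounds.

Compound 1 `c1ccc(-c2ccc(Cn3cncc3CNc3cccc(-c4ccccc4)c3)cc2)cc1`: 10000 nM
Compound 2 `CCCC(=O)c1ccc(NCc2cncn2Cc2ccc(-c3ccccc3)cc2)cc1-c1ccccc1`: > 10000 nM (a limit)
Compound 3 `c1ccc(-c2ccc(Cn3cncc3CNc3ccc(N4CCCC4)c(-c4ccccc4)c3)cc2)cc1`: > 1000 nM (a limit)

Among the measured compounds shown here, in a toxicity assay on NIH3T3 cells (Mus musculus) for cytotoxicity, read by resazurin assay (a lower number here means that less compound is needed, a higher number that more compound is needed for the effect), compound 1 gives 10000 nM as the only readable number in the set. Compound 2 stands at > 10000 nM and this is a limit. As far as these compounds go, compound 3 stands at > 1000 nM and this is also a limit, so its exact place remains open.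

Compound 4 `c1ccc(-c2ccc(Cn3cncc3CNc3ccc(-c4onc5ccccc45)c(-c4ccccc4)c3)cc2)cc1` is not yet measured. Its difference from compound 3 is a group of 9 heavy atoms (7 carbon, 1 nitrogen, 1 oxygen; one five-membered aromatic ring with 2 hetero atoms, one six-membered aromatic ring of carbon only) in place of a group of 5 heavy atoms (4 carbon, 1 nitrogen; one five-membered non-aromatic ring with 1 hetero atom), on an aromatic carbon with pyrrolidin-1-yl leaving a position ortho to a phenyl group.

The measured steps that bear on this are a number no lower from compound 1 to compound 2 (the limit leaves the size open) and a step that the limit leaves unreadable from compound 1 to compound 3 and a step that the two limits leave unreadable from compound 2 to compound 3 and each changes a group on an aromatic carbon. None has a readable size, so they support no expected direction or size of change in this assay beyond the scatter. For the measured compounds named here, with compound 1 at 10000 nM as the only number, compound 4 is expected to stay in the same high range. Compound 4 may again return only a limit. The estimated step is a step that the limit leaves unreadable from compound 3 to compound 4 and it remains loose because compound 3 gives > 1000 nM which is a limit. For compound 4 the estimated value is 8000 nM with an expected range from 1500 nM to 30000 nM in this series.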

Compound 4, half-maximal effective concentration: > 10000 nM
Compound 4: a limit, no number; the forecaster's own chance of this, stated with the estimate: 60%; at least 1.2-fold (0.09 log units) between middle value and limit.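

In this assay compound 4 gives > 10000 nM, which is a limit and not a number, so the group of 9 heavy atoms on this aromatic carbon, ortho to a phenyl group, adds no readable value to the series. Set against hydrogen at this place, the change gives a number no lower from compound 1 to compound 4 (the limit leaves the size open), and the steps to compound 4 from compound 2 and from compound 3 cannot be read. Compound 4 shares its limit with compound 2, which carries propylcarbonyl on this carbon: the limit of > 10000 nM in this assay, at which 2 of the 4 values shown sit.

As far as these compounds go, whether another group on this carbon, such as an amine or a carboxylic acid, would give a readable number in this assay stays open. From the compounds shown here alone, how far compound 2, compound 3 and compound 4 lie from compound 1, and how they rank among themselves, also stays open.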